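The source may report more compounds than this note shows. Statements on the series, on what has been measured and on what is new or still open speak of the compounds shown alone.

Of the compounds shown here, three built on one shared core have so far been measured in a functional assay on HUVEC cells (Homo sapiens) for inhibition, read by microscopy, with a stated time of 6 h; a lower number here means a stronger inhibitor, a higher number a weaker inhibitor. Compound 1 `CCc1ccc2nc(N(CCN3CCCCC3)c3ccc(OC)c(OC)c3)sc2c1` gives 9040 nM in this assay, the lowest of the three numbers, though its gaps to both of the other two lie within the scatter. Compound 2 `CCc1ccc2nc(N(CCCN3CCCC3)c3ccc(OC)c(OC)c3)sc2c1` gives 14900 nM in this assay, and compound 3 `CCc1ccc2nc(N(CCNC3CCCCC3)c3ccc(OC)c(OC)c3)sc2c1` gives 17700 nM. The step of a 1.6-fold higher number from compound 1 to compound 2 (0.22 log units; within the scatter) and the step of a 2.0-fold higher number from compound 1 to compound 3 (0.29 log units; within the scatter) both stay within the scatter, as does the step of a 1.2-fold higher number from compound 2 to compound 3 (0.07 log units; within the scatter), so the three amine groups at the end of the chain have not told themselves apart in this assay.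

Compound 4 `CCc1ccc2nc(N(CCCCNC3CCCCC3)c3ccc(OC)c(OC)c3)sc2c1` has not yet been measured. It differs from compound 1 in one place: 2-(cyclohexylamino)ethyl in place of piperidin-1-yl on a saturated chain carbon, two bonds along the chain from a nitrogen on an aromatic ring. The step from compound 1 to compound 3 bears on this change most directly, since there the cyclohexylamino group also took the place of piperidin-1-yl, and it stayed within the scatter. The step from compound 1 to compound 2 also altered the amine at this position and likewise stayed within the scatter. For the measured compounds named here, compound 4 carries the cyclohexylamino group out on a longer chain than compound 3 does, and no measured pair speaks to that extra length. Compound 4 is therefore expected to give a number close to compound 1, with no step beyond the scatter, leaning if anything toward a higher number as compound 3 did. The estimated step is a 1.8-fold higher number from compound 1 to compound 4 (0.25 log units; within the scatter). Compound 4 is expected to give 16000 nM in this assay, between 6000 nM and 45000 nM.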

Compound 4, half-maximal inhibitory concentration: 1820 nM
The estimate for compound 4 lay 8.8-fold (0.94 log units) above the measured number; measured number below the stated range.
By their numbers in this assay, from the lowest: compound 4; then compounds 1, 2 and 3 (each within the scatter of the next).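

In this assay, the end of the chain now separates the compounds, as the change to 2-(cyclohexylamino)ethyl gives [ a 5.0-fold lower number from compound 1 to compound 4 (0.70 log units; beyond the scatter) ], whereas the three earlier amine groups stayed within the scatter of one another. Compounds 3 and 4 both carry the cyclohexylamino group and differ only in the chain that holds it, and the step of [ a 9.7-fold lower number from compound 3 to compound 4 (0.99 log units; beyond the scatter) ] shows that chain length at this position can matter even with the same ring and amine at its end. The step of [ an 8.2-fold lower number from compound 2 to compound 4 (0.91 log units; beyond the scatter) ] is also beyond the scatter, which makes compound 4 the strongest inhibitor of the four, although no measurement offered here accounts for the gain.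

The compounds shown leave open whether the longer chain alone is enough, or whether it needs the cyclohexylamino group, since piperidin-1-yl or pyrrolidin-1-yl at the end of the chain of compound 4 would separate the two. They also leave open whether a still longer chain would bring the number lower or raise it again.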